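A few compounds are considered here, and "the series" means these few. Any claim that something is new, unique, unknown or untested is made for them only; others in the source may bear on it.

Two cores appear here. Compound 1 `C=CCSc1nncc2cnc(CCC)n12` carries a propyl group on one core, and compound 2 `CCCc1nc(C)c2ccnc(Nc3cc[nH]n3)n12` carries a propyl group on another; the difference between the two cores is not broken down here. Compound 3 `Cc1nc(C)n2c(Nc3cc[nH]n3)nccc12` shares the core of compound 2. Compound 4 `C=CCSc1nncc2cnc(C)n12`, still to be measured, shares the core of compound 1.

In a functional assay for inhibition, with Homo sapiens as the target (on this read-out lower numbers stand for stronger inhibition and higher numbers for weaker inhibition), compound 2 gives 25000 nM. Compound 3 gives 53000 nM. The change from compound 2 to compound 3 is hydrogen in place of ethyl on a saturated chain carbon bound to an aromatic carbon and brings a 2.1-fold higher number from compound 2 to compound 3 (0.33 log units; beyond the scatter).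

For compound 1 only a limit is known: in this assay it sits at > 48000 nM, a limit of the assay and not a number. Where compound 1 stands is thus set by the limit of > 48000 nM in this assay, at which 1 of the 3 values shown sits.

Compound 4 arises from compound 1 by hydrogen in place of ethyl on a saturated chain carbon bound to an aromatic carbon, the same change seen between compound 2 and compound 3, at the same place. On that measured step compound 3 came out weaker than compound 2, so the expectation is that compound 4 will not be stronger than compound 1, and since compound 1 already sits at a limit, compound 4 is expected to sit at or beyond that limit as well, a step that the limit leaves unreadable from compound 1 to compound 4. The estimate for compound 4 in this assay is therefore 100000 nM, expected to fall between 40000 nM and 300000 nM, most likely reported only as a limit.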

Compound 4, half-maximal inhibitory concentration: 61000 nM
Compound 4: the middle estimate sits 1.6-fold (0.21 log units) above what was measured, within the range that was stated.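

No size can be read for the step from compound 1 to compound 4 in this assay because the value of compound 1 is only a limit of the assay: the limit of > 48000 nM in this assay, at which 1 of the 4 values shown sits.

The compounds shown leave open whether replacing propyl with methyl acts on the core of compound 1 as it does on the core shared by compound 2 and compound 3.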